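A few compounds are considered here, and "the series" means these few. Any claim that something is new, unique, unknown or untested is made for them only; others in the source may bear on it.

Working notes on the series. Going by the values given here, in a functional assay on A549 cells (Homo sapiens) for cytotoxicity, read by sulforhodamine B assay (on this read-out lower numbers stand for stronger inhibition of growth and higher numbers for weaker inhibition of growth), compound 3 (`COc1ccc2c(c1)CCN2c1nc(Cl)nc2ccccc12`) gives 233 nM, the highest of the three numbers so far and beyond the scatter from both others. Compound 1 (`Cc1ccc2c(c1)CCCN2c1nc(Cl)nc2ccccc12`) gives 43 nM. Compound 2 (`COc1ccc2c(c1)C(=O)CCN2c1nc(C)nc2ccccc12`) gives 24 nM. Compound 4 (`COc1ccc2c(c1)CCN2c1nc(C)nc2ccccc12`) has methyl in place of chloro on an aromatic carbon, between two ring nitrogen atoms: methyl in place of chloro on an aromatic carbon. Among the compounds with values here, no measured pair isolates this change. Compound 1 carries chloro at that place and compound 2 carries methyl, and each differs from compound 3 elsewhere too, so they offer only weak guidance. A moderate move toward a lower number is expected in this assay, an estimated 2.1-fold lower number from compound 3 to compound 4 (0.33 log units; beyond the scatter). The expected value for compound 4 is 110 nM, with an estimated range of 35 nM to 330 nM.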

Compound 4, concentration for 50% growth inhibition: 268 nM
Compound 4: middle estimate off by 2.4-fold (0.39 log units), on the low side; measured number inside the range.
By their numbers in this assay, from the lowest: compounds 2 and 1 (each within the scatter of the next); then compounds 3 and 4 (each within the scatter of the next).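

In this assay, methyl in place of chloro on this aromatic carbon, between two ring nitrogen atoms, gives a 1.2-fold higher number from compound 3 to compound 4 (0.06 log units; within the scatter). Going by these compounds alone, this is the first direct reading of the change: on the core of compound 3, the two groups cannot be told apart at this position. No evidence is available that bears on why the number holds across this change. The compounds shown leave open whether the same equivalence holds on the cores of compound 1 and compound 2. They also leave open how an amine or a longer chain such as propyl would read at this carbon.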